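The source may report more compounds than this note shows. Statements on the series, on what has been measured and on what is new or still open speak of the compounds shown alone.

Measured compounds:
compound 1 `Cc1nnsc1C(=O)Nc1nc2ccccc2o1` — 19600 nM
compound 2 `O=C(Nc1nc2ccccc2o1)c1ccco1` — > 100000 nM
compound 3 `O=C(Nc1nc2ccccc2o1)c1ccc(Cl)s1` — "not determined" (no result reported)

In an ADME assay on HEK293 cells (Homo sapiens) for cytotoxicity, read by CCK-8 assay, with a stated time of 48 h (on this read-out lower numbers stand for stronger inhibition and higher numbers for weaker inhibition), compound 2 sits at the limit of > 100000 nM in this assay, at which 1 of the 3 values shown sits, a limit of the assay rather than a number. Compound 3 has no number in this assay, so it cannot be placed against compound 1 or compound 2. The change to compound 4 `O=C(Nc1nc2ccccc2o1)c1ccccc1` is phenyl in place of 5-chlorothiophen-2-yl on a carbonyl carbon. Among the compounds with values here, no measured step covers this pair. Within the data shown here, the only measured step, an at least 5.1-fold higher number from compound 1 to compound 2 (0.70 log units; beyond the scatter), also exchanges the group on the carbonyl carbon, and it ran towards weaker inhibition, ending at a limit. With the starting point unmeasured, no direction can be stated for the step to compound 4, and a number near the weak end of the series is expected. Compound 4 is therefore expected to give 60000 nM in this assay, with a range of 20000 nM to 150000 nM.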

Compound 4, half-maximal inhibitory concentration: > 100000 nM
Compound 4: no number, only a limit (the forecaster's own chance of this, stated with the estimate: 50%); at least 1.6-fold (0.22 log units) between middle value and limit.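

Phenyl on the carbonyl carbon, in compound 4, ends at a limit in this assay, as furan-2-yl does in compound 2: the limit of > 100000 nM in this assay, at which 2 of the 4 values shown sit.

The 4-methyl-1,2,3-thiadiazol-5-yl group now stands apart from two replacements rather than one, with phenyl giving an at least 5.1-fold higher number from compound 1 to compound 4 (0.70 log units; beyond the scatter). The step from compound 2 to compound 4 cannot be read, as both ends are limits.

With no result for compound 3, 5-chlorothiophen-2-yl remains unplaced against the other groups. Also open, going by these compounds, is where an amine or a carboxylic acid on the phenyl of compound 4 would fall in this assay.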